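This account rests on a few compounds, and the source may have more. Where it says the series, first, only, none or still open, it means among the compounds named here.

Within the data shown here, compound 3 `Cc1c(OCCCCOc2cccc(C(=O)O)c2)ccc(C(=O)CC(C)C)c1O` stands highest of the three measured members in an ADME assay (liver) for metabolic stability, with Liver microsome (Rattus norvegicus) as the target, read by LC-MS, using microsomes and NADPH, with stated times of 5 min and 60 min, tested at 4 uM (on this read-out lower numbers stand for a less stable compound and higher numbers for a more stable compound), where compound 3 gives 51%; compound 1 `Cc1c(OCCCCOc2ccc(C(=O)O)cc2Cl)ccc(C(=O)CC2CCCC2)c1O` gives 21% and compound 2 `COc1ccc(C(=O)O)cc1OCCCCOc1ccc(C(=O)CC(C)C)c(O)c1C` gives 5%. Among the measured compounds shown here, the only one-place step in hand, a number 46 percentage points higher from compound 2 to compound 3 (beyond the scatter), concerns a different change and gives no direct guide here. Compound 4 `Cc1c(OCCCCOc2ccc(C(=O)O)cc2Cl)ccc(C(=O)CC(C)C)c1O` differs from compound 3 by 4-carboxy-2-chlorophenyl in place of 3-carboxyphenyl on an oxygen on a saturated carbon. Compound 1 carries the same 4-carboxy-2-chlorophenyl group and sits well under compound 3, but it also differs in its ketone side chain, so only the two values themselves can be read. A fall beyond the scatter is therefore expected, a number 26 percentage points lower from compound 3 to compound 4 (beyond the scatter). Compound 4 is estimated at 25%, within 10% to 45%.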

Compound 4, percent of the compound remaining: 61%
For compound 4 the middle estimate is 36 percentage points below the measured one, and the stated range ends below it.
By their numbers in this assay, from the lowest: compound 2; then compound 1; then compounds 3 and 4 (each within the scatter of the next).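

In this assay, 4-carboxy-2-chlorophenyl in place of 3-carboxyphenyl on an oxygen on a saturated carbon gives a number 10 percentage points higher from compound 3 to compound 4 (within the scatter) and so leaves the read-out unresolved at this position. With 4-carboxy-2-chlorophenyl held constant, isopropyl in place of cyclopentyl on a saturated chain carbon bound to a carbonyl carbon gives a number 40 percentage points higher from compound 1 to compound 4 (beyond the scatter) as a large step, which places the low value of compound 1 with its ketone side chain. No supporting data explain either step. From the compounds shown here alone, the chlorine and the carboxy placement change together, so their separate contributions remain open. Going by these compounds, whether fluorine in place of that chlorine, or a longer chain in place of isopropyl, would keep the read-out also remains open.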